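Thiophene sulfonylureas: ring substitution pattern and whole-animal inhibition

The source may report more compounds than this note shows. Statements on the series, on what has been measured and on what is new or still open speak of the compounds shown alone.

The series shares a sulfonylurea linking a chlorophenyl group to a thiophene ring, with the thiophene carrying a small alkyl group. Compound 1 `CCc1ccc(S(=O)(=O)NC(=O)Nc2ccc(Cl)cc2)s1` carries the core of 5-ethylthiophen-2-yl; in a functional assay on the whole organism (6C3HED cells, Mus musculus) for inhibition, at a dose of 150 mg/kg by the oral route (on this read-out higher numbers stand for more inhibition at the one dose given (going by the name of the read-out) and lower numbers for less inhibition), compound 1 gives 57%. Compound 2 `CC(C)c1ccc(S(=O)(=O)NC(=O)Nc2ccc(Cl)cc2)s1` differs from it by methyl in place of hydrogen on a saturated chain carbon bound to an aromatic carbon and a saturated chain carbon, and the step of a number 15 percentage points lower from compound 1 to compound 2 (beyond the scatter), so in this assay compound 2 gives 42%.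

Compound 3 `Cc1ccsc1S(=O)(=O)NC(=O)Nc1ccc(Cl)cc1` changes the core instead: the difference is 3-methylthiophen-2-yl in place of 5-ethylthiophen-2-yl on a sulfonyl sulfur, and the step of a number 40 percentage points lower from compound 1 to compound 3 (beyond the scatter). In this assay compound 3 gives 17%, the lowest of the three numbers, with compound 2 nearest and compound 1 furthest, both beyond the scatter.

Compound 4 `CCc1ccsc1S(=O)(=O)NC(=O)Nc1ccc(Cl)cc1`, not yet measured, differs from compound 3 by methyl in place of hydrogen on a saturated chain carbon bound to an aromatic carbon. This is the same kind of change as that from compound 1 to compound 2, but not the same: there the place was on a saturated chain carbon bound to an aromatic carbon and a saturated chain carbon, here it is on a saturated chain carbon bound to an aromatic carbon only, and the cores differ as described above. Among the measured compounds shown here, the one measured example of this kind of change lowered the number, and the expectation is that it lowers it again, though from a low starting value the room for a drop is smaller; the step expected for compound 4 is a number 7 percentage points lower from compound 3 to compound 4 (within the scatter), resting on compound 1 to compound 2 with a number 15 percentage points lower from compound 1 to compound 2 (beyond the scatter) and on compound 3 with 17%. For compound 4 in this assay the estimate is 10%, expected to lie between 0% and 30%.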

Compound 4, a percentage reported as inhibition, in the whole organism at one dose (the size of the read-out at that dose, not a potency): 21%
Beside the measured number, compound 4's estimate is 11 percentage points below it, within the range that was stated.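

The added methyl does not carry over from one core to the other in this assay, the two steps differing by more than the scatter allows: the same change on two cores in this assay, a number 15 percentage points lower (beyond the scatter) from compound 1 to compound 2 and a number 4 percentage points higher (within the scatter) from compound 3 to compound 4, 19 percentage points apart, beyond the scatter of two such steps

On the core of compound 3 the step is a number 4 percentage points higher from compound 3 to compound 4 (within the scatter), so no effect of the methyl can be claimed there, whereas the ethyl-to-isopropyl pair on the core of compound 1 shows a real loss; the larger contrast in these data is the swap of 5-ethylthiophen-2-yl for 3-ethylthiophen-2-yl, which gives a number 36 percentage points lower from compound 1 to compound 4 (beyond the scatter). Among the compounds shown here, this shows only that the step measured on one core cannot be assumed on the other, and with a single pair on each core, read at one oral dose, it gives no general rule and no reason for the difference.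

The compounds shown leave open how a longer chain such as propyl or butyl would behave on either core, and whether the drop seen from compound 1 to compound 2 continues with further branching, as in a tert-butyl group. They also leave open whether a polar group such as an amine or a carboxylic acid on the thiophene, or a replacement for the chlorine on the phenyl ring, would change the picture.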